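The source may report more compounds than this note shows. Statements on the series, on what has been measured and on what is new or still open speak of the compounds shown alone.

In a functional assay for inhibition (a lower number here means a stronger inhibitor, a higher number a weaker inhibitor), two compounds sharing one core have been measured so far. Compound 1 `CC(C)(C)c1cc(-c2cc(=O)c3ccc(OCc4ccc5ccccc5n4)cc3o2)cc(C(C)(C)C)c1O` gives 3000 nM, and compound 2 `CC(C)(C)c1cc(-c2cc(=O)c3ccc(O)cc3o2)cc(C(C)(C)C)c1O` gives 1000 nM, the lower of the two numbers. Compound 3 `CCCCCCOc1ccc2c(=O)cc(-c3cc(C(C)(C)C)c(O)c(C(C)(C)C)c3)oc2c1` has yet to be measured. It differs from compound 2 by hexyl in place of hydrogen on an oxygen on an aromatic ring, hydroxy to hexyloxy: hexyl in place of hydrogen on an oxygen on an aromatic ring. Going by the values given here, one measured step bears on this change: hydrogen in place of (quinolin-2-yl)methyl on that oxygen gave a 3.0-fold lower number from compound 1 to compound 2 (0.48 log units; beyond the scatter), a modest step beyond the scatter. It is a single step with a different group, so it is only a loose guide, but it points to a modest rise in the number in this assay when hexyl enters. The expected step is a 2.8-fold higher number from compound 2 to compound 3 (0.45 log units; beyond the scatter). The estimate for compound 3 is 2800 nM, with an expected range of 900 nM to 9000 nM.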

Compound 3, half-maximal inhibitory concentration: 5000 nM
Compound 3: middle estimate off by 1.8-fold (0.25 log units), on the low side; the range from low to high includes it.
By their numbers in this assay, from the lowest: compound 2; then compounds 1 and 3 (each within the scatter of the next).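

In this assay, hexyl on the oxygen gave a 5.0-fold higher number from compound 2 to compound 3 (0.70 log units; beyond the scatter) and so joined (quinolin-2-yl)methyl as a second, quite different group that leaves the number higher than the free hydroxy of compound 2 does. The two ethers could not be told apart, with a 1.7-fold higher number from compound 1 to compound 3 (0.22 log units; within the scatter) showing that, at this oxygen, a plain hexyl chain and the (quinolin-2-yl)methyl group give results within the usual scatter. Nothing at hand explains why either group raises the number. The compounds shown leave open whether a shorter chain such as methyl or ethyl would bring the number back toward that of compound 2. They also do not show whether a hexyl chain ending in an amine or a carboxylic acid would give a lower number than the unsubstituted chain.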